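This account rests on a few compounds, and the source may have more. Where it says the series, first, only, none or still open, it means among the compounds named here.

Compound 3 `COc1cccc(CNCC(C)Oc2cccc3ccc(N)nc23)c1` gives 1 nM in an assay on cells with melanin-concentrating hormone receptor 1 (Homo sapiens) as the target, read by radioligand binding (on this read-out higher numbers stand for weaker inhibition and lower numbers for stronger inhibition), the lowest of the three numbers, while compound 2 `CC(CNC1CC1)Oc1cccc2ccc(N)nc12` gives 50 nM and compound 1 `CC(CNCC1CC1)Oc1cccc2ccc(N)nc12` gives 80 nM. The change to compound 4 `CC(CNCc1ccoc1)Oc1cccc2ccc(N)nc12` is furan-3-yl in place of 3-methoxyphenyl on a saturated chain carbon bound to an amine nitrogen. For the measured compounds named here, one measured step bears directly on this place: an 80-fold lower number from compound 1 to compound 3 (1.90 log units; beyond the scatter), a large step on going from cyclopropyl to an aromatic ring. The step of a 1.6-fold lower number from compound 1 to compound 2 (0.20 log units; within the scatter) sits on an amine nitrogen rather than on the chain carbon and was small. Furan-3-yl is still aromatic but has fewer heavy atoms than 3-methoxyphenyl, so part of that large gain is expected to be given back, a rise of about a 10-fold higher number from compound 3 to compound 4 (1.00 log units; beyond the scatter) in this assay. Compound 4 is accordingly estimated at 10 nM, with a range from 3 nM to 40 nM.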

Compound 4, half-maximal inhibitory concentration: 10 nM
Estimate against measurement, compound 4: no gap at the digits printed, within the range that was stated.
By their numbers in this assay, from the lowest: compound 3; then compound 4; then compounds 2 and 1 (each within the scatter of the next).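

Furan-3-yl keeps part of the aromatic gain at the saturated chain carbon bound to an amine nitrogen, with an 8.0-fold lower number from compound 1 to compound 4 (0.90 log units; beyond the scatter), and a 5.0-fold lower number from compound 2 to compound 4 (0.70 log units; beyond the scatter). Even so, it does not match 3-methoxyphenyl, with a 10-fold higher number from compound 3 to compound 4 (1.00 log units; beyond the scatter), so the aromatic groups on this carbon are not interchangeable. No measurement on hand accounts for this difference. The compounds shown leave open whether the difference follows the ring or the methoxy group, which unsubstituted phenyl at this place would help to separate.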